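Three weak inhibitors and an ethynylsulfanyl analogue to come

The compounds below may be only part of what the source reports. "The series", "measured", "known", "first", "only" and "open" are said of these compounds alone.

Measured so far:
Compound 1 `Cc1nc2nc(SCc3ccc(Cl)cc3)nn2c(N2CC[C@@H](C)[C@@H](N(C)c3ncnc4[nH]ccc34)C2)c1C` gives 99200 nM in a toxicity assay on GES1 cells (Homo sapiens) for inhibition, read by MTT assay, with a stated time of 72 h; on this read-out higher numbers stand for weaker inhibition and lower numbers for stronger inhibition.
Compound 2 `Cc1cc(N2CC[C@@H](C)[C@@H](N(C)c3ncnc4[nH]ccc34)C2)n2nc(SCC3CCCCC3)nc2n1` gives 98200 nM in this assay.
Compound 3 `CCc1cc(N2CC[C@@H](C)[C@@H](N(C)c3ncnc4[nH]ccc34)C2)n2ncnc2n1` reaches only the assay limit of > 100000 nM in this assay, a limit and not a number.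

All three compounds share the same core and inhibit the cells only weakly. Compound 2 stands at the lower of the two numbers recorded, with compound 1 its nearest neighbour, and the two lie within the scatter of each other, so no order can be drawn between them. Compound 3 is known only as a limit (the limit of > 100000 nM in this assay, at which 1 of the 3 values shown sits).

Compound 4 `C#CSc1nc2nc(C)cc(N3CC[C@@H](C)[C@@H](N(C)c4ncnc5[nH]ccc45)C3)n2n1` has not yet been measured. It differs from compound 2 in one place: ethynyl in place of cyclohexylmethyl on a sulfur. Within the data shown here, no step between measured compounds shows how a change on this sulfur shifts the read-out. Since the known values all sit at or near the limit of this assay, the expected step is none beyond the scatter, and a reading reported only as a limit would not be surprising. Compound 4 is therefore expected to give about 97000 nM, between 55000 nM and 100000 nM, an estimated step of a 1.0-fold lower number from compound 2 to compound 4 (0.01 log units; within the scatter).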

Compound 4, half-maximal inhibitory concentration: > 100000 nM
Compound 4: no number, only a limit; the forecaster's own chance of this, stated with the estimate: 40%; middle value at least 1.0-fold (0.01 log units) away from the limit.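

In this assay compound 4 is known only as a limit, > 100000 nM, and not as a number. Among these compounds, this gives the first reading of a change on this sulfur, an at least 1.0-fold higher number from compound 2 to compound 4 (0.00 log units; that floor lies within the scatter), so replacing cyclohexylmethyl with the much smaller ethynyl, which also removes the ring, did not bring stronger inhibition of the cells, although the true size of the step remains unknown. The earlier compounds could not show this, and the new result also adds to the readings that reach the top of the scale: the limit of > 100000 nM in this assay, at which 2 of the 4 values shown sit.

The compounds shown leave open whether any group on this sulfur can move the read-out clearly towards stronger inhibition, for instance an amine or a carboxylic acid carried on a longer chain. They also leave open how far compound 4 lies past its limit, so a further weakening from this change can be neither confirmed nor ruled out.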